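This account rests on a few compounds, and the source may have more. Where it says the series, first, only, none or still open, it means among the compounds named here.

Compound 1 `COc1cc(OC)c2c(c1)C(C(O)c1ccc(O)cc1)OC2=O` gives > 10000 nM as a limit of the assay
Compound 2 `COCCCCOc1ccc(C(O)C2OC(=O)c3c(OC)cc(OC)cc32)cc1` gives 8210 nM as a measured number
Compound 3 `CCOCCOc1ccc(C(O)C2OC(=O)c3c(OC)cc(OC)cc32)cc1` has no value yet

Going by the values given here, in a functional assay on RAW264.7 cells (Mus musculus) for inhibition, read by Griess assay, with stated times of 1 h and 24 h (a higher number here means a weaker inhibitor, a lower number a stronger inhibitor), compound 2 gives 8210 nM as the only number so far. Among the compounds with values here, the one measured step is an at least 1.2-fold lower number from compound 1 to compound 2 (0.08 log units; that floor lies within the scatter) and it starts from a limit. Compound 3 differs from compound 2 by ethoxy in place of 2-methoxyethyl on a saturated chain carbon, two bonds along the chain from an oxygen on an aromatic ring and so 4-methoxybutoxy becomes 2-ethoxyethoxy. The measured step adds the chain and does not compare chains, so no step beyond the scatter and no direction is expected in this assay here. The expected step is a 1.0-fold lower number from compound 2 to compound 3 (0.01 log units; within the scatter) in size. For compound 3 the estimated value is 8000 nM with an expected range from 3500 nM to 14000 nM overall.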

Compound 3, half-maximal inhibitory concentration: > 10000 nM
Compound 3: only a limit was reported; the forecaster's own chance of this, stated with the estimate: 30%; middle value at least 1.2-fold (0.09 log units) away from the limit.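

In this assay, going by these compounds alone, this is the first comparison of one chain with another at this position, and the change from 4-methoxybutoxy to 2-ethoxyethoxy gives an at least 1.2-fold higher number from compound 2 to compound 3 (0.08 log units; that floor lies within the scatter) and so does not separate the two chains. The true size of that step cannot be given because compound 3 is reported only as a limit: the limit of > 10000 nM in this assay, at which 2 of the 3 values shown sit. The step from compound 1 to compound 3 cannot be read.

The compounds shown leave open whether a chain carrying an amine or a carboxylic acid, or a longer chain, would give a measured number clearly lower than that of compound 2.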